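A Five-Membered Heteroaryl Urea Replaces the Naphthyl Group

The source may hold more compounds than are shown below. What is called first, only, known or untested is meant among the compounds shown, and "the series" means these compounds.

Compound 2 `O=C(Nc1ccc(Nc2ncnc3c2OCCN3)cc1)Nc1cccc2ccccc12` stands at the weak end of the pair in an assay on isolated protein for inhibition of proto-oncogene tyrosine-protein kinase receptor Ret variant V804M (Homo sapiens), read by 33P incorporation, with stated times of 15 min and 40 min; a higher number here means a weaker inhibitor, a lower number a stronger inhibitor. In this assay compound 2 reaches only a limit, > 10000 nM. Compound 1 `Cc1ccc(F)c(NC(=O)Nc2ccc(Nc3ncnc4c3OCCN4)cc2)c1` gives 5110 nM in this assay, and the step to the naphthalene was an at least 1.9-fold higher number from compound 1 to compound 2 (0.29 log units; that floor lies within the scatter). Compound 3 `CC(C)(C)c1cc(NC(=O)Nc2ccc(Nc3ncnc4c3OCCN4)cc2)no1` carries 5-(tert-butyl)-1,2-oxazol-3-yl in place of naphthalen-1-yl on an amide-type nitrogen. For the measured compounds named here, only that one measured step bears on this change, and it ended at the limit of > 10000 nM in this assay, at which 1 of the 2 values shown sits, so its true size is unknown. A modest step toward a finite number is expected, an at least 1.6-fold lower number from compound 2 to compound 3 (0.22 log units; that floor lies within the scatter). Compound 3 is therefore estimated at 6000 nM, expected between 1500 nM and 20000 nM.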

Compound 3, half-maximal inhibitory concentration: 34 nM
The estimate for compound 3 lay 180-fold (2.25 log units) above the measured number, outside the stated range (below it).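

In this assay, the group on the amide-type nitrogen turns out to matter strongly: 5-(tert-butyl)-1,2-oxazol-3-yl in place of naphthalen-1-yl gives an at least 290-fold lower number from compound 2 to compound 3 (2.46 log units; beyond the scatter), and in place of 2-fluoro-5-methylphenyl it gives a 150-fold lower number from compound 1 to compound 3 (2.18 log units; beyond the scatter). Both steps lie beyond the scatter, whereas the floor of the earlier step lay within it. The first of them is only a floor, since compound 2 stands at a limit: the limit of > 10000 nM in this assay, at which 1 of the 3 values shown sits.

From the compounds shown here alone, the ring and the tert-butyl group enter together, so it remains open which of them carries the change. A 5-methyl-1,2-oxazol-3-yl or a tert-butylphenyl group at this place would separate the two.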